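From anilino to piperidin-1-yl on a shared core

This account rests on a few compounds, and the source may have more. Where it says the series, first, only, none or still open, it means among the compounds named here.

Of the compounds shown here, three sharing one core have been tested in a functional assay on MGC-803 cells (Homo sapiens) for inhibition, read by sulforhodamine B assay; on this read-out higher numbers stand for weaker inhibition and lower numbers for stronger inhibition. Compound 1 `O=C1C=C(NCc2ccccc2)C(=O)c2c1nc1n2[C@H]2OC[C@@H](O)[C@H]2OC1` gives 2670 nM, compound 2 `O=C1C=C(Nc2cccc(F)c2)C(=O)c2c1nc1n2[C@H]2OC[C@@H](O)[C@H]2OC1` gives 2180 nM, and compound 3 `O=C1C=C(Nc2ccccc2)C(=O)c2c1nc1n2[C@H]2OC[C@@H](O)[C@H]2OC1` gives 1730 nM. Compound 3 therefore lies within the scatter of both others, and the three cannot be ranked.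

Compound 4 `O=C1C=C(N2CCCCC2)C(=O)c2c1nc1n2[C@H]2OC[C@@H](O)[C@H]2OC1` carries piperidin-1-yl in place of anilino on a double-bonded ring carbon. The closest evidence comes from changes to the group on the amine nitrogen. Phenyl in place of benzyl gave a 1.5-fold lower number from compound 1 to compound 3 (0.19 log units; within the scatter), and 3-fluorophenyl in place of benzyl gave a 1.2-fold lower number from compound 1 to compound 2 (0.09 log units; within the scatter). Hydrogen in place of fluoro on an aromatic carbon gave a 1.3-fold lower number from compound 2 to compound 3 (0.10 log units; within the scatter). All three steps are within the scatter. Among the measured compounds shown here, none of the measured compounds has piperidin-1-yl at this place, however, so they are only a weak guide.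

The expected step is a 1.4-fold higher number from compound 3 to compound 4 (0.16 log units; within the scatter), which would not go beyond the scatter. Compound 4 is estimated at 2500 nM, with an expected range from 900 nM to 7000 nM.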

Compound 4, half-maximal inhibitory concentration: > 8000 nM
Compound 4: a limit, no number; the forecaster's own chance of this, stated with the estimate: 5%; middle value at least 3.2-fold (0.50 log units) from the limit.
By their numbers in this assay, from the lowest: compounds 3, 2 and 1 (each within the scatter of the next). At a limit, above all of these: compound 4.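

In this assay compound 4 gives > 8000 nM, which is a limit of the assay and not a number. Against this limit, all three amino groups compare clearly: the steps are an at least 4.6-fold higher number from compound 3 to compound 4 (0.66 log units; beyond the scatter), an at least 3.6-fold higher number from compound 2 to compound 4 (0.56 log units; beyond the scatter) and an at least 2.9-fold higher number from compound 1 to compound 4 (0.47 log units; beyond the scatter). The earlier swaps among benzyl, phenyl and 3-fluorophenyl on the amine nitrogen stayed within the scatter, whereas this change shows that the number at this ring carbon can move beyond it, at least when piperidin-1-yl enters.

Piperidin-1-yl differs from anilino in two ways at once, with no hydrogen-bond donor and a non-aromatic ring, and the compounds shown cannot separate the two. Cyclohexylamino, with its non-aromatic ring on an amine nitrogen that still bears hydrogen, would help to tell them apart.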